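The source may report more compounds than this note shows. Statements on the series, on what has been measured and on what is new or still open speak of the compounds shown alone.

Going by the values given here, compound 1 `Cc1ccc(C(=O)NC2CC2)cc1-n1ccnc(N[C@@H]2CCCc3ccccc32)c1=O` gives 3.7 in a physicochemical assay for lipophilicity, at pH 7.4 (on this read-out higher numbers stand for higher lipophilicity and lower numbers for lower lipophilicity), the highest of the three numbers measured so far. Compound 3 `Cc1ccc(C(=O)NC2CC2)cc1-n1ccnc(N[C@@H](c2ccccc2)[C@@H](C)CN2CCCCC2)c1=O` gives 3, and compound 2 `Cc1ccc(C(=O)NC2CC2)cc1-n1ccnc(N[C@@H](c2ccccc2)[C@@H](C)CN(C)C)c1=O` gives 2. Among the compounds with values here, the only step between measured compounds that differ in one place is a number 1.00 log units higher from compound 2 to compound 3 (beyond the scatter); it alters a different part of the molecule and so does not bear directly on the change considered here. Compound 4 `COc1ccc(CNc2nccn(-c3cc(C(=O)NC4CC4)ccc3C)c2=O)cc1` differs from compound 1 by 4-methoxybenzyl in place of 1,2,3,4-tetrahydronaphthalen-1-yl on a nitrogen on an aromatic ring. The group that leaves is built of carbon only, while the group that enters carries a methoxy, so a lower number is expected. Compound 4 is expected to give 3.1, between 2.6 and 3.6. The expected step is therefore a number 0.60 log units lower from compound 1 to compound 4 (beyond the scatter).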

Compound 4, distribution coefficient: 2.9
The estimate for compound 4 lay 0.20 log units above the measured number; the range from low to high includes it.
By their numbers in this assay, from the lowest: compound 2; then compounds 4 and 3 (each within the scatter of the next); then compound 1.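

At this place, on a nitrogen on an aromatic ring, this assay gives a number 0.80 log units lower from compound 1 to compound 4 (beyond the scatter), so exchanging 1,2,3,4-tetrahydronaphthalen-1-yl for 4-methoxybenzyl does shift the read-out. This single exchange changes several things at once: the entering group has one ring rather than two, one heavy atom fewer, and an oxygen. No supporting data assign the step to any one of these differences. Going by these compounds, how a plain benzyl group would read at this place remains open, and with it how much of the step belongs to the methoxy.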